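A few compounds are considered here, and "the series" means these few. Any claim that something is new, unique, unknown or untested is made for them only; others in the source may bear on it.

In a functional assay on HeLa cells (Homo sapiens) for inhibition (a lower number here means a stronger inhibitor, a higher number a weaker inhibitor), compound 1 `Oc1cccc(-c2cc(-c3ccccc3F)cc(-c3ccccc3O)n2)c1` gives 31100 nM. Compound 2 `Oc1ccc(-c2cc(-c3ccccc3F)cc(-c3ccccc3O)n2)cc1` reaches only the limit of the assay, > 50000 nM, which is a limit and not a number (the limit of > 50000 nM in this assay, at which 1 of the 3 values shown sits). The change made is 4-hydroxyphenyl in place of 3-hydroxyphenyl on an aromatic carbon, and the step of an at least 1.6-fold higher number from compound 1 to compound 2 (0.20 log units; that floor lies within the scatter) is only a floor, since the true size is hidden by the limit (the limit of > 50000 nM in this assay, at which 1 of the 3 values shown sits). Compound 3 `Oc1cccc(-c2cc(-c3ccc(OC(F)(F)F)cc3)cc(-c3ccccc3O)n2)c1` gives 20600 nM in this assay; how the core of compound 1 and the core of compound 3 differ is not broken down here. Compound 4 `Oc1ccc(-c2cc(-c3ccc(OC(F)(F)F)cc3)cc(-c3ccccc3O)n2)cc1` carries the same kind of change, (4-hydroxyphenyl in place of 3-hydroxyphenyl on an aromatic carbon); around the place the setting differs, meta to a large group in compound 3 where compound 1 has meta to a 2-fluorophenyl group. For compound 4 the expected step of a 2.9-fold higher number from compound 3 to compound 4 (0.46 log units; beyond the scatter) rests on the step seen for compound 1 an at least 1.6-fold higher number from compound 1 to compound 2 (0.20 log units; that floor lies within the scatter). Compound 4 is thus estimated at 60000 nM, likely again only a limit.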

Compound 4, half-maximal inhibitory concentration: > 50000 nM
Compound 4: a limit, no number; the forecaster's own chance of this, stated with the estimate: 60%; the middle value lies beyond the limit too.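

In this assay, 4-hydroxyphenyl in place of 3-hydroxyphenyl gives an at least 2.4-fold higher number from compound 3 to compound 4 (0.38 log units; beyond the scatter), which can be read only as a floor. Compound 4 stands at a limit of the assay, > 50000 nM, and not at a number. The change therefore carries over to the second core in direction, with only this floor lying beyond the scatter, but its true size on either core is not shown and the two sizes cannot be compared: the same change on two cores in this assay, an at least 1.6-fold higher number (0.20 log units; that floor lies within the scatter) from compound 1 to compound 2 and an at least 2.4-fold higher number (0.38 log units; beyond the scatter) from compound 3 to compound 4; the limit leaves it open whether they differ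

Still open, going by these compounds, is how an amine or a carboxylic acid in place of the hydroxyl on this phenyl group would read in this assay. Also open, on these data alone, is whether the step holds with a group other than 2-fluorophenyl or the trifluoromethoxy-bearing phenyl elsewhere on the shared core.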